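Carboxy to chloroanilide amide on compound 1

The compounds below may be only part of what the source reports. "The series", "measured", "known", "first", "only" and "open" are said of these compounds alone.

Three compounds have numbers in a functional assay on Bel-7402 cells (Homo sapiens) for inhibition, read by MTT assay, with a stated time of 24 h, tested at 100 ug/mL; a higher number here means more inhibition of growth at the concentration tested, a lower number less inhibition of growth. Compound 1 `O=C(O)CCCCC(CCSC(=O)c1ccccc1)SC(=O)c1ccccc1` gives 81%, the highest of the three. Compound 2 `O=C(CCCCC1CCSS1)Nc1cccc(C(F)(F)F)c1` gives 61.9% and compound 3 `O=C(CCCCC(S)CCS)Nc1ccc(F)cc1` gives 11.7%, and each of these lies below the figure for compound 1 by more than the scatter.

Still to be measured is compound 4 `O=C(CCCCC(CCSC(=O)c1ccccc1)SC(=O)c1ccccc1)Nc1ccc(Cl)cc1`, which keeps the rest of compound 1 and carries (4-chlorophenyl)amino in place of hydroxy on a carbonyl carbon. Among the compounds with values here, no measured pair isolates this change. Compound 2 and compound 3 are also amides, but both differ from compound 1 elsewhere as well, so they offer only indirect guidance. Their own gap, from compound 2 at 61.9% to compound 3 at 11.7%, shows that amides in this series can land far apart, and the range has to stay wide.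

A moderate fall in this assay is expected, since compound 1 at 81% stands above both amides. The expected change is a number 15 percentage points lower from compound 1 to compound 4 (beyond the scatter). Compound 4 is estimated at 66%, with an expected range of 40% to 88%.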

Compound 4, percent growth inhibition at one concentration: "not active" (no number reported)
For compound 4 the study gives words and no number; no gap can be computed for the estimate.
By their numbers in this assay, from the lowest: compound 3; then compound 2; then compound 1.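

In this assay, within the data shown here, compound 4 is reported only in words, as "not active", so no numerical step from compound 1 to compound 4 can be read. No measurement shown bears on the cause of this result. The compounds shown leave open how far growth inhibition changes when (4-chlorophenyl)amino replaces hydroxy on the carbonyl carbon.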